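Fluoro in Place of Amino: an Expected Loss of Cytotoxicity

The source may report more compounds than this note shows. Statements on the series, on what has been measured and on what is new or still open speak of the compounds shown alone.

Compound 3 `Cc1ccc(S(=O)(=O)c2nc3ccccc3nc2Nc2ccc(N)cc2)cc1` gives 24600 nM in a functional assay on A549 cells (Homo sapiens) for cytotoxicity, read by MTT assay, with a stated time of 72 h (a higher number here means a weaker inhibitor, a lower number a stronger inhibitor), the higher of the two numbers measured here. Going by the values given here, compound 2 `COc1cc(Nc2nc3ccccc3nc2S(=O)(=O)c2ccc(C)cc2)cc(OC)c1` gives 8060 nM in this assay, and a 3.1-fold higher number from compound 2 to compound 3 (0.48 log units; beyond the scatter) is the only step between measured compounds that differ in one place. Compound 1 `O=S(=O)(c1ccccc1)c1nc2ccccc2nc1Nc1ccc(F)cc1` returned > 50000 nM in this assay, which is a limit and not a number. For compound 1 only the limit of > 50000 nM in this assay, at which 1 of the 3 values shown sits, is known.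

Compound 4 `Cc1ccc(S(=O)(=O)c2nc3ccccc3nc2Nc2ccc(F)cc2)cc1` differs from compound 3 by fluoro in place of amino on an aromatic carbon. The measured step, a 3.1-fold higher number from compound 2 to compound 3 (0.48 log units; beyond the scatter), exchanges the whole aryl group on the nitrogen and does not contain the amino-to-fluoro change, so it bears on compound 4 only loosely. Compound 1 carries the same 4-fluorophenyl group as compound 4 and reached only the limit. Compound 4 is therefore expected to give a weaker number than compound 3, an expected 1.6-fold higher number from compound 3 to compound 4 (0.21 log units; within the scatter). Compound 4 is estimated at 40000 nM, with a range from 15000 nM to 120000 nM, and a fair chance that this assay returns only a limit.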

Compound 4, half-maximal inhibitory concentration: 39200 nM
Beside the measured number, compound 4's estimate is 1.0-fold (0.01 log units) above it; measured number inside the range.
By their numbers in this assay, from the lowest: compound 2; then compounds 3 and 4 (each within the scatter of the next). At a limit, above all of these: compound 1.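

The swap of fluoro for amino on an aromatic carbon, para to a large group, gives a 1.6-fold higher number from compound 3 to compound 4 (0.20 log units; within the scatter) in this assay, so this change does not separate the two compounds. With 4-fluorophenyl in place of 3,5-dimethoxyphenyl on the nitrogen, the step is a 4.9-fold higher number from compound 2 to compound 4 (0.69 log units; beyond the scatter), so compound 2 now keeps the lower number against both compound 3 and compound 4. The step for methyl in place of hydrogen on an aromatic carbon, an at least 1.2-fold lower number from compound 1 to compound 4 (0.10 log units; that floor lies within the scatter), starts from a limit and not a number: the limit of > 50000 nM in this assay, at which 1 of the 4 values shown sits.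

From the compounds shown here alone, whether a carboxylic acid or a single methoxy at this position would move the number beyond the scatter stays open. The compounds shown also leave open how much of the lower number of compound 2 rests on each of its two methoxy groups.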